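From Methyl to Bromo on the Shared Core

This account rests on a few compounds, and the source may have more. Where it says the series, first, only, none or still open, it means among the compounds named here.

In a functional assay on HeLa cells (Homo sapiens) for cytotoxicity, read by sulforhodamine B assay, with a stated time of 48 h (a lower number here means a stronger inhibitor, a higher number a weaker inhibitor), compound 1 `O=C(c1cccnc1)c1ccccc1O` gives 33000 nM and compound 2 `Cc1ccc(O)c(C(=O)c2cccnc2)c1` gives 26000 nM on the same scale, so these two lie within the scatter of repeated measurements and cannot be ranked. Compound 3 `O=C(c1cccnc1)c1cc(Br)ccc1O` differs from compound 2 at one place (bromo in place of methyl on an aromatic carbon), with bromo in place of methyl on an aromatic carbon, para to a hydroxy group. Within the data shown here, the one measured step at this carbon (a 1.3-fold lower number from compound 1 to compound 2 (0.10 log units; within the scatter)) put methyl in place of hydrogen and stayed within the scatter. Among the measured compounds shown here, no bromo compound has been measured, so the data give no direct size for this swap. The expectation therefore stays close to compound 2 at 26000 nM in this assay with no step beyond the scatter. The estimated step is small (a 1.3-fold lower number from compound 2 to compound 3 (0.11 log units; within the scatter)). For compound 3 the estimated value is 20000 nM with an expected range from 8000 nM to 45000 nM in this measurement.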

Compound 3, half-maximal inhibitory concentration: 29000 nM
The estimate for compound 3 lay 1.5-fold (0.16 log units) below the measured number; the range from low to high includes it.
By their numbers in this assay, from the lowest: compounds 2, 3 and 1 (each within the scatter of the next).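

With bromo, this carbon, para to a hydroxy group, now carries three different substituents, and in this assay none of them separates from the others: the swap from methyl gives (a 1.1-fold higher number from compound 2 to compound 3 (0.05 log units; within the scatter)), and the comparison with hydrogen gives (a 1.1-fold lower number from compound 1 to compound 3 (0.06 log units; within the scatter)). Hydrogen, methyl and bromo therefore cannot be ranked here, so the earlier finding for methyl alone now also holds for a halogen, and compounds 1, 2 and 3 remain indistinguishable in this measurement. Nothing available offers an explanation for this flat result.

The compounds shown leave open whether a different kind of group at this carbon, such as an amine, a carboxylic acid or a longer chain, would move the number beyond the scatter. They also leave open whether replacing the hydroxy group would change the number.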